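The source may hold more compounds than are shown below. What is called first, only, known or untested is meant among the compounds shown, and "the series" means these compounds.

Of the compounds shown here, three have so far been tested in a functional assay on HeLa cells (Homo sapiens) for antiproliferative activity, read by sulforhodamine B assay; a higher number here means a weaker inhibitor of growth, a lower number a stronger inhibitor of growth. Compound 1 `CCCCCCCCCCCCCCCOC[C@H]1O[C@@H](CCC)[C@H](O)[C@@H](OCCCCCCCCCCCCCCC)[C@@H]1OCCCCCCCCCCCCCCC` gives > 50000 nM, which is a limit of the assay and not a number. Compound 2 `C=CC[C@@H]1O[C@H](COCc2ccccc2)[C@@H](OCc2ccccc2)[C@H](OCc2ccccc2)[C@H]1OC(C)=O` gives > 50000 nM, again a limit. Compound 3 `C[C@@H]1O[C@H](COCc2ccccc2)[C@@H](OCc2ccccc2)[C@H](OCc2ccccc2)C1=O` gives > 50000 nM, also a limit. Together the three mark (the limit of > 50000 nM in this assay, at which 3 of the 3 values shown sit), so compound 3 has no exact number to build on.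

Compound 4 `CCC[C@@H]1O[C@H](COCc2ccccc2)[C@@H](OCc2ccccc2)[C@H](OCc2ccccc2)C1=O` differs from compound 3 in one place: ethyl in place of hydrogen on a saturated chain carbon bound to a saturated ring carbon. Put another way, methyl becomes propyl. For the measured compounds named here, no measured pair shows what this change does. Resting on the limit of compound 3 at > 50000 nM, no step beyond the usual scatter is expected in this assay. The estimated step is a number no higher from compound 3 to compound 4 (the limit leaves the size open). For compound 4 the expected value is 50000 nM, within an estimated range from 15000 nM to 100000 nM.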

Compound 4, concentration for 50% growth inhibition: > 50000 nM
Compound 4: no number, only a limit; the forecaster's own chance of this, stated with the estimate: 75%; the middle value lies on the limit itself.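

For the compounds shown here, compound 4 gives > 50000 nM in this assay, which is a limit and not a number; compound 3 also rests on a limit, so no step between compound 3 and compound 4 can be read. The compounds shown leave open what exact value any of them has, since all sit at one limit: the limit of > 50000 nM in this assay, at which 4 of the 4 values shown sit.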